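Removing One Fluorine from the Acyl Ring of Compound 1

A few compounds are considered here, and "the series" means these few. Any claim that something is new, unique, unknown or untested is made for them only; others in the source may bear on it.

Three sulfonamide-linked benzanilides have been measured in a functional assay on HEK293 cells for agonist activity at probable G-protein coupled receptor 27 (Homo sapiens), read by a luciferase reporter and beta-arrestin recruitment, with a stated time of 10 min; a lower number here means a smaller maximal response, a higher number a larger maximal response. Compound 1 `O=C(Nc1ccc(S(=O)(=O)Nc2ccccc2)cc1)c1cc(F)c(Cl)cc1F` gives 37% and stands lowest of the three numbers: its nearest neighbour is compound 3 `O=C(Nc1ccc(S(=O)(=O)Nc2cccc(Cl)c2)cc1)c1ccc(Cl)cc1Cl`, which gives 40%, a difference that lies within the scatter, while compound 2 `CN(c1ccccc1)S(=O)(=O)c1ccc(NC(=O)c2ccc(Cl)cc2Cl)cc1` gives 50%, a gap that lies beyond it. Among the measured compounds shown here, the only step measured between neighbours that differ in one place is a number 10 percentage points lower from compound 2 to compound 3 (within the scatter), and it concerns the group on the sulfonyl sulfur, not the acyl ring.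

Compound 4 `O=C(Nc1ccc(S(=O)(=O)Nc2ccccc2)cc1)c1ccc(Cl)cc1F` differs from compound 1 by hydrogen in place of fluoro on an aromatic carbon. For the measured compounds named here, no measured step touches this part of the molecule, so nothing in the data says whether losing the fluoro should move the maximal response up, down, or not at all. The account therefore rests on the values of compounds 1 and 3, which share the same acyl ring type apart from the halogen pattern and sit close together. The maximal response of compound 4 in this assay is expected to stay near that of compound 1, with an estimated step of a number 3 percentage points higher from compound 1 to compound 4 (within the scatter). The estimate for compound 4 is 40%, with a range from 27% to 55%.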

Compound 4, largest response reached (Emax), in percent of the reference or control that the assay uses: 57%
Estimate against measurement, compound 4: 17 percentage points below; the whole stated range lies below it.
By their numbers in this assay, from the lowest: compounds 1, 3, 2 and 4 (each within the scatter of the next, the first and the last beyond it).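

In this assay, the change from 4-chloro-2,5-difluorophenyl to 4-chloro-2-fluorophenyl, with hydrogen taking the place of the fluoro group that stands ortho to a chloro group and para to a fluoro group, gives a number 20 percentage points higher from compound 1 to compound 4 (beyond the scatter), so this one position on an aromatic carbon can move the maximal response beyond the scatter. Among the compounds shown here, the earlier compounds could not show this: their only step, a number 10 percentage points lower from compound 2 to compound 3 (within the scatter), lies at the group on the sulfonyl sulfur, stays within the scatter and says nothing about this position. No available evidence bears on how the loss of this fluoro group raises the maximal response.

The compounds shown leave open whether the higher response depends on hydrogen itself, as a methyl group, a methoxy group or an amine at this same position would test. They also leave open whether the step from fluoro to hydrogen carries over when methyl(phenyl)amino or (3-chlorophenyl)amino stands on the sulfonyl sulfur in place of the phenylamino group that compound 1 and compound 4 share.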